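Dropping the chloro group from a deoxy nucleoside

The source may report more compounds than this note shows. Statements on the series, on what has been measured and on what is new or still open speak of the compounds shown alone.

This series consists of small nucleoside-like molecules built on a shared core, tested in a functional assay (Homo sapiens) for inhibition of Nucleic Acid, tested at 100 uM; on this read-out higher numbers stand for more inhibition at the one concentration tested (going by the name of the read-out) and lower numbers for less inhibition. Compound 1 `OC[C@H]1O[C@@H](n2cnc3c(NCc4ccccc4)nccc32)C[C@@H]1O` carries a benzylamino group on an aromatic carbon and gives 15%. Compound 2 `OC[C@H]1O[C@@H](n2cnc3c(Cl)nccc32)C[C@@H]1O` carries chloro at the same carbon and gives 5%, which is the lowest of the two single numbers recorded; its nearest neighbour is compound 1, and the change a number 10 percentage points lower from compound 1 to compound 2 (within the scatter) stays within the scatter. Compound 3 `OC[C@H]1O[C@@H](n2cnc3cnccc32)[C@H](O)[C@@H]1O`, which lacks any group at that carbon but carries an extra hydroxyl on the sugar, has several entries in this assay, giving 13%; 1% (2 entries); the spread between these repeats, (the several entries of compound 3 in this assay, 13%; 1% (2 entries)), shows how much the same compound can vary in this assay.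

Compound 4 `OC[C@H]1O[C@@H](n2cnc3cnccc32)C[C@@H]1O` is the next step from compound 2: hydrogen in place of chloro on an aromatic carbon. Among the measured compounds shown here, the only measured step that bears on swapping a group at this carbon is the one from compound 1 to compound 2, and it lay within the scatter. For the measured compounds named here, nothing measured so far suggests that removing chloro should move this assay beyond the scatter, so compound 4 is expected to give roughly 6%, between -6% and 18%, meaning an expected step of a number 1 percentage points higher from compound 2 to compound 4 (within the scatter).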

Compound 4, a percentage reported as inhibition, at one concentration (the size of the read-out at that concentration, not a potency): 6%
Estimate against measurement, compound 4: no gap at the digits printed, and the stated range covers the measured number.
By their numbers in this assay, from the lowest: compounds 2, 4 and 1 (each within the scatter of the next).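

Among the compounds shown here, at this aromatic carbon, next to the ring nitrogen, hydrogen now gives a reference point that the earlier compounds lacked, so each substituent can be set against having no group at all. In this assay, removing chloro gives a number 1 percentage points higher from compound 2 to compound 4 (within the scatter), and removing benzylamino gives a number 9 percentage points lower from compound 1 to compound 4 (within the scatter). Neither chloro nor benzylamino can therefore be said to change the read-out compared with plain hydrogen, and small differences among such low numbers deserve little weight because repeat readings of one compound can themselves spread widely: the several entries of compound 3 in this assay, 13%; 1% (2 entries)

The compounds shown leave open whether any group at this carbon can raise inhibition beyond the scatter, since chloro and benzylamino are only two possibilities and each was read at one concentration. From the compounds shown here alone, a simple amine, a methoxy group or a carboxylic acid at this carbon would test that question further, and it also remains open whether such swaps would behave the same way on the sugar with the extra hydroxyl found in compound 3.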